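The source may report more compounds than this note shows. Statements on the series, on what has been measured and on what is new or still open speak of the compounds shown alone.

Measured so far in a functional assay on DU-145 cells (Homo sapiens) for inhibition, read by trypan blue exclusion, with a stated time of 96 h; a lower number here means a stronger inhibitor of growth, a higher number a weaker inhibitor of growth:

Compound 1, `O=C(/C(=C\c1ccc(Cl)cc1)SCc1ccc(Cl)cc1)c1ccc(Br)cc1`: 10000 nM
Compound 2, `O=C(/C(=C\c1cccc(Cl)c1Cl)SCc1ccc(Cl)cc1)c1ccc(Br)cc1`: 10000 nM
Compound 3, `O=C(/C(=C\c1cc(Cl)cc(Cl)c1Cl)SCc1ccc(Cl)cc1)c1ccc(Br)cc1`: 1000 nM

Compound 1 stands level with compound 2, and together they give the highest of the three numbers. The step of no change at the digits printed from compound 1 to compound 2 (within the scatter) stays within the scatter. Compound 3 sits apart: the step of a 10-fold lower number from compound 1 to compound 3 (1.00 log units; beyond the scatter) and the step of a 10-fold lower number from compound 2 to compound 3 (1.00 log units; beyond the scatter) both go beyond the scatter. All three of these steps concern the aryl group on the double-bonded chain carbon; none of them alters the group on the sulfur.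

Compound 4, `O=C(/C(=C\c1ccc(Cl)cc1)Sc1ccc(Br)cc1)c1ccc(Br)cc1`, is compound 1 changed at that sulfur: 4-bromophenyl in place of 4-chlorobenzyl on a sulfur. Going by the values given here, no measured step bears on this change, since the sulfur substituent is the same in compounds 1, 2 and 3. With nothing in the measured set pointing either way, the step of no change at the digits printed from compound 1 to compound 4 (within the scatter) is expected to stay within the scatter. Compound 4 is therefore estimated at 10000 nM in this assay, with a range from 3000 nM to 30000 nM, the upper end allowing that the value may come back as a limit rather than a number.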

Compound 4, concentration for 50% growth inhibition: 1000 nM
Compound 4: middle estimate off by 10-fold (1.00 log units), on the high side; measured number below the stated range.
By their numbers in this assay, from the lowest: compounds 3 and 4 (each within the scatter of the next); then compounds 1 and 2 (each within the scatter of the next).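

The group on the sulfur proves able to move the number in this assay: (4-chlorobenzyl)sulfanyl to (4-bromophenyl)sulfanyl gives a 10-fold lower number from compound 1 to compound 4 (1.00 log units; beyond the scatter), with the 4-chlorophenyl group on the double-bonded chain carbon left unchanged. Going by these compounds alone, earlier, only changes to that aryl group had gone beyond the scatter, so this is the first sign that a second place on the shared core also matters, with a step as large as a 10-fold lower number from compound 2 to compound 3 (1.00 log units; beyond the scatter). Nothing measured here bears on why this change lowers the number.

The compounds shown do not separate the shift from benzyl to phenyl from the exchange of chlorine for bromine, which 4-chlorophenyl or 4-bromobenzyl on the sulfur would tell apart. They also leave open whether the change carries over to the 2,3,5-trichlorophenyl group of compound 3, and how a longer chain such as 2-phenylethyl on the sulfur would read.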